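From trifluoromethyl to bromo: compound 2 to compound 3

A few compounds are considered here, and "the series" means these few. Any claim that something is new, unique, unknown or untested is made for them only; others in the source may bear on it.

Measured in an ADME assay on HepG2 cells (Homo sapiens) for cytotoxicity, read by MTT assay, with a stated time of 72 h (on this read-out higher numbers stand for weaker inhibition and lower numbers for stronger inhibition), so far:
Compound 1 `Cc1ccc(S(=O)(=O)Cc2nc(Nc3cccc(Br)c3)c3ccccc3n2)cc1` gives > 15000 nM (a limit)
Compound 2 `CC(C)=Cc1nc(Nc2cccc(C(F)(F)F)c2)c2cc([N+](=O)[O-])ccc2n1` gives > 100000 nM (a limit)

Compound 2 gives > 100000 nM in this assay, and this is a limit and not a number. Compound 1 also has only a limit, > 15000 nM in the same read-out.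

Compound 3 `CC(C)=Cc1nc(Nc2cccc(Br)c2)c2cc([N+](=O)[O-])ccc2n1` has not yet been measured. It differs from compound 2 by bromo in place of trifluoromethyl on an aromatic carbon of a six-membered aromatic ring of carbon only, meta to a large group (bromo in place of trifluoromethyl on an aromatic carbon).

Both values in hand are limits, and no measured step sizes this exchange. In this assay no step beyond the scatter is expected, in either direction. That expectation rests on compound 2 and its limit of > 100000 nM as the only close reference. The estimated step is an at least 1.2-fold lower number from compound 2 to compound 3 (0.09 log units; that floor lies within the scatter) and is expected to stay within the scatter. Compound 3 is expected to give 80000 nM as a central estimate, with 25000 nM to 200000 nM as the estimated range, and the read-out may well return only a limit again.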

Compound 3, half-maximal inhibitory concentration: > 15000 nM
Compound 3: only a limit was reported; the forecaster's own chance of this, stated with the estimate: 70%; the middle value lies beyond the limit too.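

In this assay compound 3 gives > 15000 nM, which is a limit and not a number. Within the data shown here, compound 2 also has only a limit, > 100000 nM, so no step between compound 2 and compound 3 can be read. The compounds shown leave open whether bromo in place of trifluoromethyl on an aromatic carbon shifts the value in this assay at all, and at what concentration any of them reaches half-maximal inhibition.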